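This account rests on a few compounds, and the source may have more. Where it says the series, first, only, none or still open, it means among the compounds named here.

Measured so far in a functional assay on PC-3 cells (Homo sapiens) for inhibition, read by MTT assay, with a stated time of 48 h, tested at 10 uM; a lower number here means less inhibition of growth, a higher number more inhibition of growth at the concentration tested:
Compound 1 `Cc1cc(=O)c2c(O)cc(OCc3ccc(Br)cc3)c([C@H]3CCN(C)C[C@H]3O)c2o1`: 17%
Compound 2 `CCOC(=O)N1CCN(Cc2c(O)c([C@H]3CCN(C)C[C@H]3O)c3oc(C)cc(=O)c3c2O)CC1`: 1%
Compound 3 `Cc1oc2c([C@H]3CCN(C)C[C@H]3O)c(O)cc(O)c2c(=O)c1C(O)c1ccc([N+](=O)[O-])cc1`: 24%

Compound 3 gives 24% in this assay. This number lies within the usual scatter of compound 1 and beyond the scatter above compound 2, so compound 3 belongs to the upper pair of this small set.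

The next compound to be tested, compound 4 `Cc1oc2c([C@H]3CCN(C)C[C@H]3O)c(O)cc(O)c2c(=O)c1C(O)c1c(F)cccc1Cl`, differs from compound 3 in a single place: 2-chloro-6-fluorophenyl in place of 4-nitrophenyl on a saturated chain carbon bound to an aromatic carbon and an oxygen on a saturated carbon. In words, 2-chloro-6-fluorophenyl stands in place of 4-nitrophenyl on a saturated chain carbon bound to an aromatic carbon and an oxygen on a saturated carbon.

Going by the values given here, no two measured compounds differ in one place only, so the data hold no direct guide to the size or direction of this step. Among the compounds with values here, the only guide is the modest range of the measured numbers, with compound 2 at 1% and compound 3 at 24%. No change beyond the scatter is therefore expected in this assay, and the estimated step, a number 2 percentage points lower from compound 3 to compound 4 (within the scatter), is small. For compound 4 the expected value is 22%, with an estimated range from 6% to 40%.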

Compound 4, percent growth inhibition at one concentration: 0%
Compound 4: middle estimate off by 22 percentage points, on the high side; the whole stated range lies above it.
By their numbers in this assay, from the lowest: compounds 4 and 2 (each within the scatter of the next); then compounds 1 and 3 (each within the scatter of the next).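

In this assay, going by these compounds alone, the step of a number 24 percentage points lower from compound 3 to compound 4 (beyond the scatter) gives the first direct reading of a single change in this set, and it shows that the group on a saturated chain carbon bound to an aromatic carbon and an oxygen on a saturated carbon is not a silent spot for this read-out. Exchanging 4-nitrophenyl for 2-chloro-6-fluorophenyl keeps one six-membered aromatic ring of carbon only in that place, yet it replaces the nitrogen and both oxygens of the leaving group with a fluorine and a chlorine, and the number falls by more than the scatter of repeated measurements. Nothing measured on the properties of these groups accounts for the fall, so the step stands here as an observation without an explanation.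

Because the entering group differs from the leaving one in several features at once, this single pair cannot tell whether losing the nitro group or gaining the two halogens matters more. Where a plain phenyl or a phenyl carrying an amine would fall relative to compound 3 and compound 4 remains an open question.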